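The source may hold more compounds than are shown below. What is called first, only, known or untested is meant among the compounds shown, and "the series" means these compounds.

Compound 1 `COc1ccc(-c2cnc3nc(N)nc(N4CCN(C(=O)Nc5cccc(C)c5)CC4)c3n2)cc1OC` and compound 2 `COc1ccc(-c2cnc3nc(N)nc(N4CCN(C(=O)Nc5ccc(C#N)cc5)CC4)c3n2)cc1OC` share a core and differ only in the group attached to a urea nitrogen. In a functional assay on cells (T-cell, Homo sapiens) for inhibition (a lower number here means a stronger inhibitor, a higher number a weaker inhibitor), compound 1 gives 7 nM, while compound 2 gives 74 nM. The single step between them, an 11-fold higher number from compound 1 to compound 2 (1.02 log units; beyond the scatter), is large, and compound 2 therefore holds the higher of the two numbers shown, with compound 1 as its only neighbour.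

Compound 3 `COc1ccc(-c2cnc3nc(N)nc(N4CCN(Cc5c(Cl)cccc5Cl)CC4)c3n2)cc1OC` is not yet measured. It differs from compound 2 in one place: 2,6-dichlorobenzyl in place of (4-cyanophenyl)carbamoyl on an amine nitrogen in a ring. The whole carbamoyl group with its aryl ring is removed, and a benzyl group carrying two chlorines is attached directly to the ring nitrogen instead.

For the measured compounds named here, only one measured step exists, and it concerns a swap of one aryl group for another on the urea; no measured pair shows what removing the carbamoyl unit itself does. That step shows the region is sensitive, so a change beyond the scatter seems likely, though its direction is uncertain. A modest weakening is expected, a 2.0-fold higher number from compound 2 to compound 3 (0.31 log units; beyond the scatter), giving compound 3 an estimated 150 nM, within a wide range from 20 nM to 1200 nM.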

Compound 3, half-maximal inhibitory concentration: 7600 nM
Estimate against measurement, compound 3: 51-fold (1.70 log units) below; the measured number lies above the stated range.
By their numbers in this assay, from the lowest: compound 1; then compound 2; then compound 3.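

For the compounds shown here, the earlier step swapped only one aryl group on the urea and gave an 11-fold higher number from compound 1 to compound 2 (1.02 log units; beyond the scatter). Replacing the whole carbamoyl unit with 2,6-dichlorobenzyl on the ring nitrogen costs far more in this assay, giving a 100-fold higher number from compound 2 to compound 3 (2.01 log units; beyond the scatter) and a 1100-fold higher number from compound 1 to compound 3 (3.04 log units; beyond the scatter), which makes compound 3 the weakest inhibitor of the three. The loss is large from both urea compounds, so at this position the result depends on more than the choice of aryl group, although nothing shown explains why.

This single change removes the carbonyl and the amide hydrogen, changes the link to the aromatic ring and replaces that ring's substituents, so the compounds shown cannot say how much of the loss belongs to each part. An unsubstituted benzyl group on the same ring nitrogen would help to separate these parts, as would a urea bearing a 2,6-dichlorophenyl group, since each changes only part of what differs between compound 2 and compound 3.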